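The source may report more compounds than this note shows. Statements on the series, on what has been measured and on what is new or still open speak of the compounds shown alone.

The measured compounds are these. Compound 1, `Nc1nc(N)c2c(-c3ccsc3)cn([C@@H]3O[C@H](CO)[C@@H](O)[C@H]3O)c2n1`, gives > 20000 nM in a functional assay on HeLa S3 cells (Homo sapiens) for antiproliferative activity, read by XTT assay, with a stated time of 72 h; a lower number here means a stronger inhibitor, a higher number a weaker inhibitor. Compound 2, `Cc1ncnc2c1c(-c1cccs1)cn2[C@@H]1O[C@H](CO)[C@@H](O)[C@H]1O`, gives > 15000 nM in this assay. Compound 3, `CN(C)c1ncnc2c1c(-c1cc3ccccc3o1)cn2[C@@H]1O[C@H](CO)[C@@H](O)[C@H]1O`, gives > 20000 nM in this assay.

Each of these three values is a limit of this assay and not a number. Compound 2 stands at the limit of > 15000 nM in this assay, at which 1 of the 3 values shown sits. Compound 1 and compound 3 sit at the limit of > 20000 nM in this assay, at which 2 of the 3 values shown sit. Within the data shown here, no compound among the three reached a measurable concentration, so no step between two measured compounds can be drawn and no ordering among them is possible.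

Compound 4, `CNc1ncnc2c1c(-c1cccs1)cn2[C@@H]1O[C@H](CO)[C@@H](O)[C@H]1O`, differs from compound 2 in one place: methylamino in place of methyl on an aromatic carbon. Among the measured compounds shown here, without any measured step to lean on, the only guide is that compound 2 sits at the limit of > 15000 nM in this assay, at which 1 of the 3 values shown sits, and that compound 1 and compound 3 sit at the limit of > 20000 nM in this assay, at which 2 of the 3 values shown sit. On that basis the step of an at least 1.5-fold lower number from compound 2 to compound 4 (0.17 log units; that floor lies within the scatter) is expected to be small, at most within the scatter, with no clear direction. Compound 4 is therefore estimated at 10000 nM. Its range is expected to run from 1500 nM to 40000 nM. For compound 4 there is a fair chance that this assay again reports only a limit.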

Compound 4, half-maximal inhibitory concentration: > 20000 nM
Compound 4: a limit, no number; the forecaster's own chance of this, stated with the estimate: 60%; middle value at least 2.0-fold (0.30 log units) away from the limit.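

In this assay compound 4 gives > 20000 nM, which is a limit of the assay and not a number. Among these compounds, compound 2 also gives only a limit, and no step from compound 2 to compound 4 can be read. The compounds shown leave open how methylamino in place of methyl on an aromatic carbon affects the value in this assay.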